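Succinimide to thiazolidinedione exchange in an aryl ether series

The source may report more compounds than this note shows. Statements on the series, on what has been measured and on what is new or still open speak of the compounds shown alone.

Measured so far:
compound 1 `O=C1CC(Cc2ccc(Oc3ccc(Cl)cc3Cl)cc2)C(=O)N1` — 6450 nM
compound 2 `O=C1NC(=O)C(Cc2ccc(Oc3ncccc3C(F)(F)F)cc2)S1` — 2290 nM

Of the compounds shown here, two have been measured in a functional assay for agonist activity at Free fatty acid receptor 1 (Homo sapiens), read by FLIPR, in the presence of a further agent that is not named here; on this read-out lower numbers stand for an effect already at smaller amounts and higher numbers for an effect only at larger amounts of compound. Compound 1 gives 6450 nM in this assay, the highest of the two numbers; compound 2 gives 2290 nM in this assay, a lower number, and the gap between them lies beyond the usual scatter. The two differ in more than one place, so this gap cannot be assigned to a single structural change.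

Compound 3 `O=C1NC(=O)C(Cc2ccc(Oc3ccc(Cl)cc3Cl)cc2)S1` keeps the aryl ether of compound 1 and differs from it only at the core: 2,4-dioxo-1,3-thiazolidin-5-yl in place of 2,5-dioxopyrrolidin-3-yl on a saturated chain carbon bound to an aromatic carbon. Within the data shown here, no step between measured compounds covers this exchange on its own; the only other compound bearing the 2,4-dioxo-1,3-thiazolidin-5-yl group is compound 2, whose lower number in this assay belongs with a different aryl ether.

A step toward a lower number is expected for compound 3, of moderate size, a 2.6-fold lower number from compound 1 to compound 3 (0.41 log units; beyond the scatter), rather than a large one. Compound 3 is estimated at 2500 nM in this assay, with a range from 900 nM to 7000 nM.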

Compound 3, half-maximal effective concentration: 101 nM
For compound 3 the middle estimate is 25-fold (1.39 log units) above the measured one; measured number outside the range, below it.
By their numbers in this assay, from the lowest: compound 3; then compound 2; then compound 1.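

Notes on the core exchange: in this assay, with the aryl ether held constant, 2,4-dioxo-1,3-thiazolidin-5-yl in place of 2,5-dioxopyrrolidin-3-yl gives a 64-fold lower number from compound 1 to compound 3 (1.81 log units; beyond the scatter), which ties a large change in this read-out to this one place, something the earlier pair of compounds, differing in more than one place, could not do. The position on the saturated chain carbon bound to an aromatic carbon is thus highly sensitive to the identity of the group, even though the two groups have the same heavy-atom count and differ only in a sulfur for a ring carbon, in the hetero atoms and in the hydrogen-bond acceptors counted. No measurement at hand bears on what lies behind the step.

The compounds shown leave open whether the exchange has a step of similar size with the aryl ether of compound 2, as the series holds only one matched pair. They also leave open whether a carboxylic acid on the same saturated chain carbon would keep a number as low as that of compound 3 in this assay.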